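A few compounds are considered here, and "the series" means these few. Any claim that something is new, unique, unknown or untested is made for them only; others in the source may bear on it.

Measured compounds:
compound 1 `Nc1ccccc1NC(=O)/C=C/c1ccc(Cn2cnc3c(Nc4cccc(OC(F)(F)F)c4)nc(Cl)nc32)cc1`: 5.23%
compound 2 `CCCCn1cnc2c(Nc3ccccc3)nc(NCOCc3ccc(/C=C/C(=O)Nc4ccccc4N)cc3)nc21`: 51.9%
compound 3 `Nc1ccccc1NC(=O)c1ccc(Cn2cnc3c(Nc4cccc(OC(F)(F)F)c4)nc(Cl)nc32)cc1`: 46.6%

In a functional assay on HCT-116 cells (Homo sapiens) for antiproliferative activity, read by CCK-8 assay, with a stated time of 72 h, tested at 8 uM (on this read-out lower numbers stand for a weaker effect and higher numbers for a stronger effect at the one concentration tested), compound 1 gives 5.23%, while compound 3 gives 46.6%. The structural change between the two is (2-aminophenyl)carbamoyl in place of 2-((2-aminophenyl)carbamoyl)ethenyl on an aromatic carbon, and it made the step of a number 41.4 percentage points higher from compound 1 to compound 3 (beyond the scatter). Compound 2 gives 51.9%; how its core differs from the core of compound 1 is not broken down here. Compound 4 `CCCCn1cnc2c(Nc3ccccc3)nc(NCOCc3ccc(C(=O)Nc4ccccc4N)cc3)nc21` is not yet measured. It differs from compound 2 by (2-aminophenyl)carbamoyl in place of 2-((2-aminophenyl)carbamoyl)ethenyl on an aromatic carbon, the same change as from compound 1 to compound 3, at the same place. A gain is expected, but a smaller one than a number 41.4 percentage points higher from compound 1 to compound 3 (beyond the scatter), because compound 2 already starts from 51.9% and the read-out cannot exceed full inhibition; the step is estimated as a number 20.1 percentage points higher from compound 2 to compound 4 (beyond the scatter). Compound 4 is therefore expected to give about 72%, between 48% and 92%.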

Compound 4, a percentage reported as inhibition, at one concentration (the size of the read-out at that concentration, not a potency): 74.9%
The estimate for compound 4 lay 2.9 percentage points below the measured number; measured number inside the range.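

In this assay, (2-aminophenyl)carbamoyl in place of 2-((2-aminophenyl)carbamoyl)ethenyl gives a number 23 percentage points higher from compound 2 to compound 4 (beyond the scatter) on the second core, so the direction of the change holds on both cores shown. Two pairs do not show what sets the size of the step, whether the core itself or the starting value, and they say nothing about a third core. The size of the step does not carry over unchanged: the same change on two cores in this assay, a number 41.4 percentage points higher (beyond the scatter) from compound 1 to compound 3 and a number 23 percentage points higher (beyond the scatter) from compound 2 to compound 4, 18.4 percentage points apart, beyond the scatter of two such steps

Open, on these data alone, is whether the gain persists with a hydroxamic acid or a carboxylic acid in place of (2-aminophenyl)carbamoyl. Also open, as far as these compounds go, is whether a saturated two-carbon chain in place of the ethenyl link behaves like the ethenyl or like the direct carbamoyl attachment.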